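The source may hold more compounds than are shown below. What is called first, only, known or untested is meant among the compounds shown, and "the series" means these compounds.

In a functional assay on HT-29 cells (Homo sapiens) for inhibition, read by luminescence and CellTiter-Glo, with a stated time of 24 h (a lower number here means that less compound is needed, a higher number that more compound is needed for the effect), three compounds sharing one core have been measured, and they differ only in the group on an aromatic nitrogen. Compound 1 (`CN1C(=S)[C@@H](NC(=O)c2nc(Cc3ccccc3)n(CCCC#N)n2)COc2ccccc21`) gives 2400 nM and compound 2 (`CN1C(=S)[C@@H](NC(=O)c2nc(Cc3ccccc3)n(C3CCOCC3)n2)COc2ccccc21`) gives 2260 nM in this read-out, which makes a 1.1-fold lower number from compound 1 to compound 2 (0.03 log units; within the scatter) the smallest step. Compound 3 (`CN1C(=S)[C@@H](NC(=O)c2nc(Cc3ccccc3)n(CC3CCOCC3)n2)COc2ccccc21`) gives 6310 nM and holds the highest number of the three. It is separated from the others by a 2.6-fold higher number from compound 1 to compound 3 (0.42 log units; beyond the scatter) and by a 2.8-fold higher number from compound 2 to compound 3 (0.45 log units; beyond the scatter) on the same scale.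

Compound 4 (`Cc1cnc(-n2nc(C(=O)N[C@H]3COc4ccccc4N(C)C3=S)nc2Cc2ccccc2)nc1`) comes next, with 5-methylpyrimidin-2-yl in place of (oxan-4-yl)methyl on an aromatic nitrogen is the whole change. Within the data shown here, no measured compound carries an aromatic ring at this place, so the three steps give only a general idea of how much this position moves the number. None of them is larger than modest, and the largest is a 2.8-fold higher number from compound 2 to compound 3 (0.45 log units; beyond the scatter) in size. Since compound 3 stands at the top at 6310 nM in the series, a modest move toward a lower number is expected. The expected step is a 2.1-fold lower number from compound 3 to compound 4 (0.32 log units; beyond the scatter) in this assay by this reasoning, though the range also allows no real change.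

For compound 4 the estimated value is 3000 nM with an expected range of 900 nM to 10000 nM in this assay for now.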

Compound 4, half-maximal effective concentration: 1950 nM
Beside the measured number, compound 4's estimate is 1.5-fold (0.19 log units) above it, and the stated range covers the measured number.
By their numbers in this assay, from the lowest: compounds 4, 2 and 1 (each within the scatter of the next); then compound 3.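

The only aromatic ring at this place, 5-methylpyrimidin-2-yl, leaves the series in this assay with one level shared by three different groups: the exchange for (oxan-4-yl)methyl gives a 3.2-fold lower number from compound 3 to compound 4 (0.51 log units; beyond the scatter), while the exchange for oxan-4-yl gives a 1.2-fold lower number from compound 2 to compound 4 (0.06 log units; within the scatter) and the exchange for 3-cyanopropyl gives a 1.2-fold lower number from compound 1 to compound 4 (0.09 log units; within the scatter). Among these compounds, the position therefore accepts a six-membered aromatic ring with two hetero atoms, and the difference between an aromatic and a non-aromatic six-membered ring directly on the aromatic nitrogen does not separate compound 4 from compound 2 on this scale, leaving compound 3 as the only compound apart from the others. No supporting data bear on why this exchange gives the step it does.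

Still open, as far as these compounds go, is whether any group at this place can take the number clearly below the level shared by compounds 1, 2 and 4. The series also leaves unresolved what the methyl on the pyrimidine contributes and how an unsubstituted phenyl ring, a piperidine amine or a chain ending in a carboxylic acid would compare on the same core.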